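Removing the aryl group from the amidine nitrogen

The compounds below may be only part of what the source reports. "The series", "measured", "known", "first", "only" and "open" are said of these compounds alone.

Three compounds share one core and differ only in the aryl group on an amine nitrogen. Compound 1 `COc1ccc(N/C(CCNC2=CC(=O)c3ccccc3C2=O)=N\S(=O)(=O)c2ccc(C)cc2)cc1` gives 12000 nM in a functional assay on DU-145 cells (Homo sapiens) for cytotoxicity, read by MTT assay, with a stated time of 48 h (on this read-out lower numbers stand for stronger inhibition and higher numbers for weaker inhibition), compound 2 `Cc1ccc(S(=O)(=O)/N=C(/CCNC2=CC(=O)c3ccccc3C2=O)Nc2ccccc2I)cc1` gives 11700 nM, and compound 3 `Cc1ccc(S(=O)(=O)/N=C(/CCNC2=CC(=O)c3ccccc3C2=O)Nc2cc(F)c(F)c(F)c2)cc1` gives 12600 nM. Compound 3 holds the highest of the three numbers, yet all three sit within the scatter of one another, as the steps of a 1.0-fold lower number from compound 1 to compound 2 (0.01 log units; within the scatter), a 1.1-fold higher number from compound 1 to compound 3 (0.02 log units; within the scatter) and a 1.1-fold higher number from compound 2 to compound 3 (0.03 log units; within the scatter) show. Compound 4 `Cc1ccc(S(=O)(=O)/N=C(\N)CCNC2=CC(=O)c3ccccc3C2=O)cc1` differs from compound 3 by hydrogen in place of 3,4,5-trifluorophenyl on an amine nitrogen. Every measured step swaps one aryl group for another; none removes it altogether, so the measured steps bear only loosely on this change. Compound 4 is therefore expected to give roughly 15000 nM (range 5000 nM to 50000 nM), a step of a 1.2-fold higher number from compound 3 to compound 4 (0.08 log units; within the scatter) that is expected to stay within the scatter.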

Compound 4, half-maximal inhibitory concentration: 30900 nM
Compound 4: middle estimate off by 2.1-fold (0.31 log units), on the low side, and the stated range covers the measured number.
By their numbers in this assay, from the lowest: compounds 2, 1 and 3 (each within the scatter of the next); then compound 4.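

The aryl swaps among compounds 1, 2 and 3 left the number in this assay within the scatter, but removing the aryl group from the amine nitrogen gives a modest rise beyond it: a 2.5-fold higher number from compound 3 to compound 4 (0.39 log units; beyond the scatter) and a 2.6-fold higher number from compound 2 to compound 4 (0.42 log units; beyond the scatter) and a 2.6-fold higher number from compound 1 to compound 4 (0.41 log units; beyond the scatter). Having one of these aryl groups on this nitrogen therefore goes with a lower number than having hydrogen there, though the three aryl groups themselves cannot be told apart. No measurement shown explains this step.

Going by these compounds, whether a methyl or benzyl group on this nitrogen would keep the number near those of the aryl compounds stays open. So does whether any other aryl group could bring it well below them.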